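The compounds below may be only part of what the source reports. "The series", "measured", "known", "first", "only" and "open" are said of these compounds alone.

Compound 1 `Nc1cncc(-c2cnc(N)nc2)c1`: in an assay on isolated protein for binding affinity to phosphatidylinositol 4,5-bisphosphate 3-kinase catalytic subunit beta isoform (Homo sapiens) (on this read-out lower numbers stand for tighter binding and higher numbers for weaker binding), compound 1 gives > 40000 nM, which is a limit of the assay and not a number.
Compound 2 `CC(=O)Nc1cncc(-c2cnc(N)nc2)c1`: in this assay compound 2 gives > 20000 nM, again a limit rather than a number.

Compound 2 therefore stands at a limit, and where it lies beyond that limit is not known. The step that the two limits leave unreadable from compound 1 to compound 2, acetyl in place of hydrogen on a nitrogen on an aromatic ring, joins two limits and has no readable size, as the limit of > 20000 nM in this assay, at which 1 of the 2 values shown sits, and the limit of > 40000 nM in this assay, at which 1 of the 2 values shown sits, show. Compound 3 `CS(=O)(=O)Nc1cncc(-c2cnc(N)nc2)c1` differs from compound 2 by methylsulfonyl in place of acetyl on a nitrogen on an aromatic ring. For the measured compounds named here, no measured step with a readable size bears on this exchange. With both measured values sitting at limits, the expectation for compound 3 is that this assay again reports only a limit, so the step that the limit leaves unreadable from compound 2 to compound 3 is expected to stay within the scatter. Compound 3 is estimated at 30000 nM, within 8000 nM to 100000 nM.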

Compound 3, dissociation constant: 5200 nM
The estimate for compound 3 lay 5.8-fold (0.76 log units) above the measured number, outside the stated range (below it).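

At this nitrogen on an aromatic ring, the change from acetamido to methanesulfonamido brings the first readable number among the compounds shown in this assay, with an at least 3.8-fold lower number from compound 2 to compound 3 (0.58 log units; beyond the scatter). Methylsulfonyl in place of hydrogen on the same nitrogen gives an at least 7.6-fold lower number from compound 1 to compound 3 (0.88 log units; beyond the scatter), so the group at this place can move the read-out, and which group stands there matters. The first of these steps gives only a minimum size because compound 2 stands at a limit: the limit of > 20000 nM in this assay, at which 1 of the 3 values shown sits.

The step that joins the two limits of compound 1 and compound 2 still cannot be read, so nothing is known about what acetyl does at this nitrogen. As far as these compounds go, it also stays open whether a longer chain on the sulfonyl, such as ethylsulfonyl, or a phenylsulfonyl group would lower the number further.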